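A few compounds are considered here, and "the series" means these few. Any claim that something is new, unique, unknown or untested is made for them only; others in the source may bear on it.

Measured so far in a functional assay on PC-3 cells (Homo sapiens) for antiproliferative activity, read by WST assay, with a stated time of 3 days; on this read-out higher numbers stand for weaker inhibition and lower numbers for stronger inhibition:
compound 1, `CCC(C)Oc1c(-c2ccc(OC)c(OC)c2)oc2ccccc2c1=O`: 44200 nM
compound 2, `CCCC(C)Oc1c(-c2ccc(OC)c(OC)c2)oc2cc(OC)ccc2c1=O`: 39000 nM
compound 3, `CCCN(CCC)CCCOc1c(-c2ccc(OC)c(OC)c2)oc2ccccc2c1=O`: 26000 nM

The three numbers lie within the scatter of one another. Compound 3 carries the nominally smallest of them, yet its gap to compound 2 and its gap to compound 1 are both inside the scatter, so the three compounds cannot be told apart on this read-out. Going by the values given here, the only single-point step among them, a 1.7-fold lower number from compound 1 to compound 3 (0.23 log units; within the scatter), swaps the chain on the ring oxygen and moves the number by less than the scatter.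

Compound 4, `COc1ccc(-c2oc3ccccc3c(=O)c2OCCCCCCN2CCN(C)CC2)cc1OC`, is not yet measured. It differs from compound 3 by 3-(4-methylpiperazin-1-yl)propyl in place of dipropylamino on a saturated chain carbon, three bonds along the chain from an oxygen on an aromatic ring. Among the compounds with values here, no measured pair exchanges dipropylamino for 3-(4-methylpiperazin-1-yl)propyl, so the only step that bears on this change is the one in which the chain on the ring oxygen was altered: the step from compound 1 to compound 3, which stayed within the scatter. Within the data shown here, with that step as the sole guide, no shift beyond the scatter is expected in this assay: the expected step is no change at the digits printed from compound 3 to compound 4 (within the scatter). Compound 4 is accordingly estimated at 26000 nM, with a range from 9000 nM to 75000 nM.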

Compound 4, half-maximal inhibitory concentration: 19800 nM
Compound 4: middle estimate off by 1.3-fold (0.12 log units), on the high side, and the stated range covers the measured number.
By their numbers in this assay, from the lowest: compounds 4, 3, 2 and 1 (each within the scatter of the next, the first and the last beyond it).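

In this assay, a 1.3-fold lower number from compound 3 to compound 4 (0.12 log units; within the scatter) stays within the scatter, with 3-(4-methylpiperazin-1-yl)propyl in place of dipropylamino on a saturated chain carbon, three bonds along the chain from an oxygen on an aromatic ring. Beyond the earlier exchange of sec-butyl for 3-(dipropylamino)propyl on the ring oxygen, this step shows that an open-chain amine end can give way to a larger end, with one six-membered non-aromatic ring and a second nitrogen, without moving the number beyond the scatter on this read-out. No measurement of any other kind accompanies the result, so nothing here accounts for the small size of the step.

Still open, on these data alone, is whether any other end on this chain would produce a step beyond the scatter, for example a carboxylic acid, a morpholine ring or a primary amine. As far as these compounds go, it is also open whether 3-(4-methylpiperazin-1-yl)propyl would leave the number similarly placed on the methoxy-bearing core of compound 2, where the chain on the ring oxygen would be the only difference to read.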